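Compound 2 to compound 4: changing the carbonyl substituent

The compounds below may be only part of what the source reports. "The series", "measured", "known", "first", "only" and "open" are said of these compounds alone.

Measured so far in a functional assay on NCI-H1975 cells (Homo sapiens) for antiproliferative activity; on this read-out lower numbers stand for stronger inhibition and higher numbers for weaker inhibition:
- compound 1 `Cc1c2c(n3c1CCCN(C)[C@@H](C)[C@H](C)Nc1cc-3ccc1C(N)=O)CC(C)(C)CC2=O`: 69 nM
- compound 2 `Cc1c2c(n3c1CCN(C(=O)CN)C[C@@H](C)[C@H](C)Nc1cc-3ccc1C(N)=O)CC(C)(C)CC2=O`: 190 nM
- compound 3 `COCCC(=O)N1CCCc2c(C)c3c(n2-c2ccc(C(N)=O)c(c2)N[C@@H](C)[C@@H]1C)CC(C)(C)CC3=O`: 37 nM

Compound 2, at 190 nM, has the highest number of the three, and its gaps to compound 1 and to compound 3 both lie beyond the scatter. The next structure is compound 4 `Cc1c2c(n3c1CCN(C(=O)[C@H](C)O)C[C@@H](C)[C@H](C)Nc1cc-3ccc1C(N)=O)CC(C)(C)CC2=O`, which carries 1-hydroxyethyl in place of aminomethyl on a carbonyl carbon.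

Going by the values given here, no measured step covers this change directly. Among the compounds with values here, the only step available is a 1.9-fold lower number from compound 1 to compound 3 (0.27 log units; within the scatter), a swap of methyl for (2-methoxyethyl)carbonyl, and it stays within the scatter. It is weak evidence, since compound 2 differs from compound 1 and compound 3 in more than one place. Still, compound 3, whose carbonyl also bears no aminomethyl, stands at 37 nM, so a modest move towards a lower number in this assay is expected. The expected step is a 1.9-fold lower number from compound 2 to compound 4 (0.28 log units; within the scatter). For compound 4 the estimated value is 100 nM, with an expected range of 35 nM to 280 nM.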

Compound 4, half-maximal inhibitory concentration: 52 nM
Compound 4: middle estimate off by 1.9-fold (0.28 log units), on the high side; measured number inside the range.
By their numbers in this assay, from the lowest: compounds 3, 4 and 1 (each within the scatter of the next); then compound 2.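

On the carbonyl carbon whose other neighbours are the amide-type nitrogen in a ring, 1-hydroxyethyl in place of aminomethyl gives a 3.7-fold lower number from compound 2 to compound 4 (0.56 log units; beyond the scatter) in this assay. Going by these compounds alone, this is the first step that lies beyond the scatter, so the group on this carbonyl carbon can shift the number. The two groups have equal counts of hydrogen-bond donors and acceptors and neither carries a net charge, so those counts do not separate them, and nothing shown explains the step.

Still open, on these data alone, is whether the step follows the exchange of nitrogen for oxygen, the extra carbon or the defined stereocentre. Hydroxymethyl, 1-aminoethyl and the opposite stereoisomer of 1-hydroxyethyl on the same carbonyl carbon would tell these apart.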